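A few compounds are considered here, and "the series" means these few. Any claim that something is new, unique, unknown or untested is made for them only; others in the source may bear on it.

In an ADME assay on HepG2 2.2.15 cells (Homo sapiens) for cytotoxicity, read by CCK-8 assay, with a stated time of 8 days (a lower number here means that less compound is tolerated, a higher number that more compound is tolerated), compound 1 `COc1cccc(C(=O)Nc2c[nH]c(=O)c(-c3cccc(C)c3)c2)c1O` gives > 100000 nM, which is a limit of the assay and not a number. Among the measured compounds shown here, compound 2 `CCOc1ccc(-c2cc(NC(=O)c3cc(OC)ccc3O)c[nH]c2=O)cc1` gives 57700 nM, the only actual number so far, so it can be ranked against no other measured value. Compound 3 `CCOc1ccc(-c2cc(NC(=O)c3cccc(OC)c3O)c[nH]c2=O)cc1` has the same atoms as compound 2, joined differently, and the change lies on a carbonyl carbon whose other neighbour is an amide-type nitrogen: 2-hydroxy-3-methoxyphenyl in place of 2-hydroxy-5-methoxyphenyl (2-hydroxy-3-methoxyphenyl in place of 2-hydroxy-5-methoxyphenyl on a carbonyl carbon). For the measured compounds named here, no step between measured compounds is available to size this change. Compound 1 also carries the 2-hydroxy-3-methoxyphenyl, and its > 100000 nM is a limit. On that slender basis, the expected 1.2-fold higher number from compound 2 to compound 3 (0.08 log units; within the scatter) is small, towards more compound tolerated, and may stay within the usual scatter. Compound 3 is estimated at 70000 nM, with an expected range of 30000 nM to 100000 nM.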

Compound 3, half-maximal cytotoxic concentration: 34500 nM
Compound 3: the middle estimate sits 2.0-fold (0.31 log units) above what was measured; low and high end bracket the measured number.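

Placing 2-hydroxy-3-methoxyphenyl in place of 2-hydroxy-5-methoxyphenyl on the carbonyl carbon gives the first measured size for this change in this assay: a 1.7-fold lower number from compound 2 to compound 3 (0.22 log units; within the scatter) and so the two compounds cannot be told apart. At the other varied place, 4-ethoxyphenyl in place of 3-methylphenyl on an aromatic carbon gives an at least 2.8-fold lower number from compound 1 to compound 3 (0.46 log units; beyond the scatter) and this is the first step shown to exceed the scatter, with less compound tolerated. Compound 1 gives > 100000 nM as a limit and not a number, and this step therefore has only a minimum size: the limit of > 100000 nM in this assay, at which 1 of the 3 values shown sits.

The compounds shown leave open whether the two hydroxy-methoxyphenyl groups would also stay within the scatter of each other with a group other than 4-ethoxyphenyl on the aromatic carbon. Also open, from the compounds shown here alone, is how an amine, a carboxylic acid or a longer chain in place of the ethoxy group would read.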